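A few compounds are considered here, and "the series" means these few. Any claim that something is new, unique, unknown or untested is made for them only; others in the source may bear on it.

In a functional assay on KYSE-450 cells (Homo sapiens) for inhibition, read by MTT assay, with a stated time of 48 h (on this read-out lower numbers stand for stronger inhibition and higher numbers for weaker inhibition), compound 1 `CCC/C=C/C(=O)N(Cc1ccc(OC)c(O)c1)c1cc(OC)c(OC)c(OC)c1` gives 57 nM, the lowest of the three numbers recorded. Compound 3 `C/C=C/C(=O)N(Cc1ccc(OC)c([N+](=O)[O-])c1)c1cc(OC)c(OC)c(OC)c1` gives 510 nM, and compound 2 `COc1ccc(CNc2cc(OC)c(OC)c(OC)c2)cc1Br` gives 39800 nM; both lie beyond the scatter above compound 1, compound 2 by a wide margin. Compound 4 `COc1ccc(CN(C(=O)CO)c2cc(OC)c(OC)c(OC)c2)cc1O` has not yet been tested. It differs from compound 1 in one place: hydroxymethyl in place of pent-1-en-1-yl on a carbonyl carbon. Within the data shown here, no measured pair shows this change on its own. The step is nonetheless expected to be a clear loss, a 26-fold higher number from compound 1 to compound 4 (1.42 log units; beyond the scatter), since compound 2 with no acyl group at all on the amide-type nitrogen gives 39800 nM, far above compound 1. Compound 4 is therefore estimated at 1500 nM, with a likely range from 300 nM to 8000 nM.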

Compound 4, half-maximal inhibitory concentration: 370 nM
Beside the measured number, compound 4's estimate is 4.1-fold (0.61 log units) above it, within the range that was stated.
By their numbers in this assay, from the lowest: compound 1; then compounds 4 and 3 (each within the scatter of the next); then compound 2.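

In this assay, hydroxymethyl in place of pent-1-en-1-yl on a carbonyl carbon gives a 6.5-fold higher number from compound 1 to compound 4 (0.81 log units; beyond the scatter), a modest loss that lies beyond the scatter. This position therefore accepts a much smaller group that brings a hydrogen-bond donor, and compound 4 still gives 370 nM, although pent-1-en-1-yl remains the better of the two groups. Nothing available here explains the step. Among these compounds, the single change does not separate the loss of the double bond from the shorter chain or the entering hydroxymethyl. From the compounds shown here alone, how a methyl, a propyl or an aminomethyl group would fare at this carbonyl carbon remains open.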